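Chain extension on the unsubstituted core

The compounds below may be only part of what the source reports. "The series", "measured", "known", "first", "only" and "open" are said of these compounds alone.

Compound 3 `O=C(CCCCC(=O)Nc1nc2ccccc2s1)NO` gives 10.2 ug/mL in a functional assay on ASPC1 cells (Homo sapiens) for cytotoxicity (on this read-out lower numbers stand for stronger inhibition and higher numbers for weaker inhibition), the higher of the two plain numbers at hand. Compound 2 `COc1ccc2nc(NC(=O)CCCCCCC(=O)NO)sc2c1` gives 0.79 ug/mL in this assay; it differs from compound 3 both in the methoxy on the core and in the chain, so its lower number cannot be assigned to either change alone. Compound 1 `CS(=O)(=O)c1ccc2nc(NC(=O)CCCCC(=O)NO)sc2c1` returns only a limit, > 30 ug/mL, in this assay. Within the data shown here, the sole one-place step, an at least 2.9-fold lower number from compound 1 to compound 3 (0.46 log units; beyond the scatter), concerns the aromatic substituent and not the chain, so it does not bear on the move to compound 4 `O=C(CCCCCCC(=O)Nc1nc2ccccc2s1)NO`: 2-(hydroxycarbamoyl)ethyl in place of hydroxycarbamoyl on a saturated chain carbon, four bonds along the chain from a carbonyl carbon. Compound 4 is expected to give 2 ug/mL (range 0.7 ug/mL to 6 ug/mL). The expected step of a 5.1-fold lower number from compound 3 to compound 4 (0.71 log units; beyond the scatter) toward a lower number rests on compound 2 carrying the same longer chain and giving 0.79 ug/mL.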

Compound 4, half-maximal inhibitory concentration: 5.69 ug/mL
Beside the measured number, compound 4's estimate is 2.8-fold (0.45 log units) below it; the measured number falls inside the stated range.
By their numbers in this assay, from the lowest: compound 2; then compounds 4 and 3 (each within the scatter of the next). At a limit, above all of these: compound 1.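

On the unsubstituted core, 2-(hydroxycarbamoyl)ethyl in place of hydroxycarbamoyl gives no change that can be told from scatter in this assay (a 1.8-fold lower number from compound 3 to compound 4 (0.25 log units; within the scatter)). On the longer chain, the methoxy does separate two compounds (a 7.2-fold higher number from compound 2 to compound 4 (0.86 log units; beyond the scatter)), so the low number of compound 2 goes with the methoxy and not with the chain alone. No measurement shown here accounts for either step.

From the compounds shown here alone, whether methoxy gives a similar step on the shorter chain remains open. So does the effect of an amine or carboxylic acid on the aromatic carbon, or of a still longer chain.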